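The source may report more compounds than this note shows. Statements on the series, on what has been measured and on what is new or still open speak of the compounds shown alone.

Compound 1 `COCCOc1cc(/C=C/c2ccc3ccccc3c2)ccc1OC`: 2990 nM
Compound 2 `COc1ccc(/C=C/c2ccc3ccccc3c2)cc1`: > 5000 nM

These two compounds were tested in a functional assay on SK-MEL-28 cells (Homo sapiens) for inhibition; on this read-out lower numbers stand for stronger inhibition and higher numbers for weaker inhibition. Compound 2 gives > 5000 nM, and this is a limit of the assay, not a number. The data show this as the limit of > 5000 nM in this assay, at which 1 of the 2 values shown sits. Among the compounds with values here, the one measured step is an at least 1.6-fold higher number from compound 1 to compound 2 (0.22 log units; that floor lies within the scatter), and it replaces 2-methoxyethoxy with hydrogen on an aromatic carbon.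

Compound 3 `COc1ccc(/C=C/c2ccc3ccccc3c2)cc1F` is built from compound 2 by one change, (fluoro in place of hydrogen on an aromatic carbon). The fluoro sits on an aromatic carbon, ortho to a methoxy group and meta to a large group. Within the data shown here, no measured step covers fluoro, so the step from compound 1 offers only a loose guide, and its size is known only as a floor. With so small a substituent entering, no clear move in this assay is expected in either direction. The expected change is a number no higher from compound 2 to compound 3 (the limit leaves the size open), which would not stand out from the scatter. A report of compound 3 as a limit alone would be no surprise. For compound 3 the estimated value is 5000 nM, with an expected range from 2000 nM to 12000 nM.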

Compound 3, half-maximal inhibitory concentration: > 5000 nM
Compound 3 ended at the assay's limit (the forecaster's own chance of this, stated with the estimate: 60%); the middle value sits exactly at the limit.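

Fluoro in place of hydrogen at this position, ortho to a methoxy group, does not bring the compound to a readable value in this assay: compound 3 gives > 5000 nM, which is a limit of the assay and not a number. The step between compound 2 and compound 3 cannot be read, as both of its ends are limits, and the other new step, fluoro in place of 2-methoxyethoxy on the same carbon, is an at least 1.6-fold higher number from compound 1 to compound 3 (0.22 log units; that floor lies within the scatter). Compound 1, with its 2-methoxyethoxy group, thus stays the only compound shown with a number, and the other two rest at one ceiling: the limit of > 5000 nM in this assay, at which 2 of the 3 values shown sit.

From the compounds shown here alone, whether fluoro has any effect at all on this carbon stays open, and so does the true size of the gap between either compound at the limit and compound 1. It also remains to be seen whether a hydroxy group, an amine or a longer ether chain on this carbon would give a readable number, and so whether the chain of compound 1 matters through its length or through its oxygen atoms.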